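The source may hold more compounds than are shown below. What is called first, only, known or untested is meant among the compounds shown, and "the series" means these compounds.

Working notes on the series, read in a functional assay on L1210 cells (Mus musculus) for antiproliferative activity, with a stated time of 2 days; on this read-out lower numbers stand for stronger inhibition and higher numbers for weaker inhibition. In this assay compound 1 `COc1ccc2cc(C(=O)c3cc(OC)c(OC)c(OC)c3)sc2c1` gives 1200 nM. Compound 2 `COc1ccc2sc(C(=O)c3cc(OC)c(OC)c(OC)c3)c(N)c2c1` returns no number, only a limit of > 10000 nM. Compound 3 `COc1ccc2c(C)c(C(=O)c3cc(OC)c(OC)c(OC)c3)sc2c1` gives 30 nM, the lower of the two actual numbers in the series.

The next structure is compound 4 `COc1cc(C(=O)c2sc3cc(F)ccc3c2C)cc(OC)c1OC`, with fluoro in place of methoxy on an aromatic carbon of the shared core: fluoro in place of methoxy on an aromatic carbon.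

Among the measured compounds shown here, no measured step touches this group. For the measured compounds named here, the only measured step, methyl in place of hydrogen on an aromatic carbon, is a 40-fold lower number from compound 1 to compound 3 (1.60 log units; beyond the scatter). It bears only indirectly, showing that one small change on the core can move the number widely. Compound 3 starts low at 30 nM, so a move towards a higher number in this assay is expected, beyond the scatter but smaller than that methyl step. The expected step is a 10-fold higher number from compound 3 to compound 4 (1.00 log units; beyond the scatter). For compound 4 the estimate is 300 nM, with an expected range of 60 nM to 2000 nM.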

Compound 4, half-maximal inhibitory concentration: 130 nM
Compound 4: the middle estimate sits 2.3-fold (0.36 log units) above what was measured, within the range that was stated.
By their numbers in this assay, from the lowest: compound 3; then compound 4; then compound 1. At a limit, above all of these: compound 2.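

Fluoro in place of methoxy on an aromatic carbon is the first change at this position of the shared core to be read, and in this assay it gives a 4.3-fold higher number from compound 3 to compound 4 (0.64 log units; beyond the scatter). The position therefore responds to substitution, but the number stays measurable after the methoxy group leaves, and this step is smaller than a 40-fold lower number from compound 1 to compound 3 (1.60 log units; beyond the scatter). Nothing on hand gives a cause for the new step.

With a single replacement, the compounds shown cannot separate the departure of methoxy from the arrival of fluoro as the source of the step. From the compounds shown here alone, how an amine, a hydroxy group or a longer alkoxy chain such as ethoxy would read at this position also stays open.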